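Replacing Quinoline with a Trifluoromethyl Styryl Amide

A few compounds are considered here, and "the series" means these few. Any claim that something is new, unique, unknown or untested is made for them only; others in the source may bear on it.

Compound 2 `CN1[C@@H]2c3[nH]c4ccccc4c3C[C@H]1[C@H](C#N)N1[C@@H](CNC(=O)c3ccc4ccccc4n3)c3[nH]c4ccccc4c3C[C@@H]21` — in a functional assay on MCF7 cells (Homo sapiens) for cytotoxicity, read by MTT assay, with a stated time of 72 h (on this read-out lower numbers stand for stronger inhibition and higher numbers for weaker inhibition), compound 2 gives 150 nM.
Compound 1 `CN1[C@@H]2c3[nH]c4ccccc4c3C[C@H]1[C@H](C#N)N1[C@@H](CNC(=O)c3ccc4ccccc4c3)c3[nH]c4ccccc4c3C[C@@H]21` — in this assay compound 1 gives 4650 nM.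

Compound 2 stands at the lowest of the two numbers. Within the data shown here, the only measured step is a 31-fold lower number from compound 1 to compound 2 (1.49 log units; beyond the scatter), a large gain. Compound 3 `CN1[C@@H]2c3[nH]c4ccccc4c3C[C@H]1[C@H](C#N)N1[C@@H](CNC(=O)/C=C/c3cccc(C(F)(F)F)c3)c3[nH]c4ccccc4c3C[C@@H]21` differs from compound 2 by 2-(3-(trifluoromethyl)phenyl)ethenyl in place of quinolin-2-yl on a carbonyl carbon. That single step bears on it: the quinolin-2-yl which gave the gain now leaves, and the entering group, like naphthalen-2-yl, brings no hydrogen-bond acceptor, so a weaker number is expected. The estimate for compound 3 is 2000 nM, with a range from 500 nM to 8000 nM, meaning an expected step of a 13-fold higher number from compound 2 to compound 3 (1.12 log units; beyond the scatter).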

Compound 3, half-maximal inhibitory concentration: 110 nM
Beside the measured number, compound 3's estimate is 18-fold (1.26 log units) above it; the measured number lies below the stated range.
By their numbers in this assay, from the lowest: compounds 3 and 2 (each within the scatter of the next); then compound 1.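

At this place, on a carbonyl carbon, the hydrogen-bond acceptor of quinolin-2-yl is not required for a number like that of compound 2: in this assay 2-(3-(trifluoromethyl)phenyl)ethenyl, which has no such acceptor, gives a 1.4-fold lower number from compound 2 to compound 3 (0.13 log units; within the scatter) as the step. Naphthalen-2-yl has no such acceptor either, yet replacing it with the same group gives a 42-fold lower number from compound 1 to compound 3 (1.63 log units; beyond the scatter) as the step, so acceptor count alone does not separate these groups. No available measurement explains either step.

The compounds shown leave open how much the double bond and the trifluoromethyl group each contribute. A carboxylic acid or an amine in place of the trifluoromethyl group also remains an open case.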